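The compounds below may be only part of what the source reports. "The series", "measured", "known", "first", "only" and "open" are said of these compounds alone.

In an in vivo ADME assay on the whole organism for metabolic stability, with Mus musculus as the target, read by LC-MS, at a dose of 320 mg/kg by the oral route (on this read-out lower numbers stand for a shorter-lived compound and higher numbers for a longer-lived compound), compound 2 (`CC(C)/N=C(\NC1=NC(=O)CN1C(C)C)Nc1ccc(Cl)c(Cl)c1`) gives 0.283 h and stands level with compound 1 (`CC(C)NC(=N)NC1=NC(=O)CN1c1cccc(Cl)c1Cl`) at 0.225 h within the scatter, while compound 3 (`CC(C)/N=C(\NC1=NC(=O)CN1C)Nc1ccc(Cl)c(Cl)c1`) gives 0.83 h on the same read-out. Compound 4 (`CCOC(=O)/N=C(\NC1=NC(=O)CN1C(C)C)Nc1ccc(Cl)c(Cl)c1`) differs from compound 2 by one change (ethoxycarbonyl in place of isopropyl on a double-bonded nitrogen): ethoxycarbonyl in place of isopropyl on a double-bonded nitrogen. For the measured compounds named here, the only measured step that also removes an isopropyl (a 2.9-fold higher number from compound 2 to compound 3 (0.47 log units; beyond the scatter)) puts methyl on an amine nitrogen in a ring, a different place, so it offers no direct guide, and no measured step brings in ethoxycarbonyl. In this assay no shift beyond the scatter is therefore expected (a 1.1-fold higher number from compound 2 to compound 4 (0.03 log units; within the scatter)). For compound 4 the expected half-life is 0.3 h (estimated range 0.1 h to 0.9 h).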

Compound 4, half-life: > 1 h
Compound 4: a limit, no number; the forecaster's own chance of this, stated with the estimate: 3%; at least 3.3-fold (0.52 log units) between middle value and limit.
By their numbers in this assay, from the lowest: compounds 1 and 2 (each within the scatter of the next); then compound 3. At a limit, above all of these: compound 4.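

For the compounds shown here, until now the only step beyond the scatter lay on an amine nitrogen in a ring; in this assay a change on the double-bonded nitrogen also moves the read-out, with an at least 3.5-fold higher number from compound 2 to compound 4 (0.54 log units; beyond the scatter). Compound 4 gives > 1 h, which is a limit and not a number. The step therefore has a lower bound but no measured size: the limit of > 1 h in this assay, at which 1 of the 4 values shown sits.

As far as these compounds go, it remains open how an acetyl group or a methoxycarbonyl group on this nitrogen would read. Also open, from the compounds shown here alone, is whether ethoxycarbonyl would shift the half-life in the same way with methyl on the amine nitrogen in a ring, as in compound 3.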